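The source may hold more compounds than are shown below. What is called first, only, known or untested is meant among the compounds shown, and "the series" means these compounds.

Of the compounds shown here, two have so far been measured in an assay on cells for agonist activity at Bombesin receptor subtype-3 (Mus musculus), read by HTRF and inositol phosphate accumulation, with a stated time of 1 h; a lower number here means that less compound is needed, a higher number that more compound is needed for the effect. Compound 1, `COC(=O)c1c(F)cccc1-c1ccc(CCc2ncc(CC(C)(C)C)n2CCO)cc1`, gives 24 nM. Compound 2, `CC(C)(C)Cc1cnc(CCc2ccc(-c3cccc(F)c3C(=O)O)cc2)n1Cc1ccc(C(=O)O)cc1`, gives 13 nM. Of the two numbers that of compound 2 is the lower one, but the two values lie within the usual scatter of each other, so no order between them can be read from these figures.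

Compound 3, `CC(C)(C)Cc1cnc(CCc2ccc(-c3cccc(F)c3C(=O)O)cc2)n1CCO`, is compound 2 with one change: hydroxymethyl in place of 4-carboxyphenyl on a saturated chain carbon bound to an aromatic nitrogen. Compound 1 already carries the same 2-hydroxyethyl group on that aromatic nitrogen, and in this assay compound 1 gives 24 nM, close to the value of compound 2. Because compound 1 gives 24 nM in this assay while carrying that same group, the step from compound 2 to compound 3 is expected to stay within the scatter. The estimated step is a 1.5-fold higher number from compound 2 to compound 3 (0.19 log units; within the scatter). For compound 3 in this assay a value of about 20 nM is expected, with a likely range from 7 nM to 60 nM.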

Compound 3, half-maximal effective concentration: 2 nM
Compound 3: the middle estimate sits 10-fold (1.00 log units) above what was measured; the measured number lies below the stated range.
By their numbers in this assay, from the lowest: compound 3; then compounds 2 and 1 (each within the scatter of the next).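

In this assay, the position on the aromatic nitrogen turns out not to need the large 4-carboxybenzyl group: the smaller 2-hydroxyethyl group, which has no ring, gives a 6.5-fold lower number from compound 2 to compound 3 (0.81 log units; beyond the scatter) and so brings a clear gain. With the 2-hydroxyethyl group held constant, the free carboxylic acid also gives a clearly lower number than its methyl ester, with hydrogen in place of methyl on an oxygen next to a carbonyl group giving a 12-fold lower number from compound 1 to compound 3 (1.08 log units; beyond the scatter) as the step. Nothing available explains why either change lowers the number.

From the compounds shown here alone, it remains open whether a longer chain ending in hydroxyl, or an amine in place of the hydroxyl, would keep the number this low. Going by these compounds, it also remains open whether the ester-to-acid step would be the same size alongside the 4-carboxybenzyl group.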